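Anilino variation on the shared core: towards compound 3

The source may report more compounds than this note shows. Statements on the series, on what has been measured and on what is new or still open speak of the compounds shown alone.

Measured compounds:
compound 1 `COc1cc(-c2nc(SCc3cn(CC(=O)NC(=O)Nc4ccccn4)nn3)nc(Nc3ccc(C)cc3)c2C#N)cc(OC)c1OC`: 32 nM
compound 2 `COc1cc(-c2nc(SCc3cn(CC(=O)NC(=O)Nc4ccccn4)nn3)nc(Nc3cccc(C(F)(F)F)c3)c2C#N)cc(OC)c1OC`: 24400 nM

Among the compounds with values here, compound 2 stands at the higher of the two numbers so far in a functional assay on B16-F10 cells (Mus musculus) for inhibition, read by MTT assay, with a stated time of 72 h; on this read-out higher numbers stand for weaker inhibition and lower numbers for stronger inhibition; its only neighbour is compound 1, and the one step recorded, a 760-fold higher number from compound 1 to compound 2 (2.88 log units; beyond the scatter), is large and lies well beyond the scatter. Compound 3 `COc1cc(-c2nc(SCc3cn(CC(=O)NC(=O)Nc4ccccn4)nn3)nc(Nc3ccc(Cl)cc3)c2C#N)cc(OC)c1OC` has not been measured. It differs from compound 2 by 4-chlorophenyl in place of 3-(trifluoromethyl)phenyl on a nitrogen on an aromatic ring. The step from compound 1 to compound 2 is the only one that bears on this position, and it shows that the group on this nitrogen moves the number over a wide span. Within the data shown here, compound 3 carries a 4-chlorophenyl, which shares its substitution pattern with the 4-methylphenyl of compound 1 rather than with the 3-(trifluoromethyl)phenyl of compound 2; no measured pair tells how chlorine compares with methyl here. A large drop in this assay is therefore expected, a 200-fold lower number from compound 2 to compound 3 (2.31 log units; beyond the scatter), bringing compound 3 near compound 1 but with wide uncertainty. Compound 3 is estimated at 120 nM, with a range from 20 nM to 2500 nM.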

Compound 3, half-maximal inhibitory concentration: 1110 nM
For compound 3 the middle estimate is 9.3-fold (0.97 log units) below the measured one; low and high end bracket the measured number.
By their numbers in this assay, from the lowest: compound 1; then compound 3; then compound 2.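

In this assay, within the data shown here, a 22-fold lower number from compound 2 to compound 3 (1.34 log units; beyond the scatter) shows that most of the loss seen with 3-(trifluoromethyl)phenyl on this nitrogen is absent with 4-chlorophenyl, so compound 2 no longer stands as the only guide to how an aryl group behaves here, though this step changes both the group and its place on the ring. Among these compounds, the pair with 4-methylphenyl and 4-chlorophenyl is the first in which only the ring substituent changes, chloro in place of methyl on an aromatic carbon, and a 35-fold higher number from compound 1 to compound 3 (1.54 log units; beyond the scatter) shows that this single exchange is itself large, with compound 1 keeping the lowest number of the three. No measurement at hand accounts for either step.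

The three compounds do not separate the effect of the identity of the substituent from that of its place on the ring in the step between trifluoromethyl and chloro, as no two of them carry the same substituent at different places. On these data alone, how an unsubstituted phenyl, a methoxy-bearing phenyl or an amine-bearing phenyl on this nitrogen would read remains open.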